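The source may hold more compounds than are shown below. What is called first, only, known or untested is meant among the compounds shown, and "the series" means these compounds.

Compound 3 `N#CC1=C(N)Oc2c(N)cc3nc4ccccc4nc3c2C12C(=O)N(Cc1cnnn1-c1cccc(C(F)(F)F)c1)c1ccccc12` carries a 3-(trifluoromethyl)phenyl group on an aromatic nitrogen of a five-membered aromatic ring with 3 nitrogen. In a functional assay on HCT-116 cells (Homo sapiens) for antiproliferative activity, read by MTT assay, with a stated time of 48 h (a lower number here means a stronger inhibitor, a higher number a weaker inhibitor), compound 3 gives 18900 nM. Two companions share the same core. Compound 1 `N#CC1=C(N)Oc2c(N)cc3nc4ccccc4nc3c2C12C(=O)N(Cc1cnnn1-c1ccc(F)cc1)c1ccccc12` carries a 4-fluorophenyl group on that nitrogen. In this assay compound 1 reaches only a limit, > 50000 nM, meaning (the limit of > 50000 nM in this assay, at which 1 of the 3 values shown sits). Compound 2 `N#CC1=C(N)Oc2c(N)cc3nc4ccccc4nc3c2C12C(=O)N(Cc1cnnn1-c1cccc(Br)c1)c1ccccc12` carries a 3-bromophenyl group there and gives 26100 nM. Compound 3 thus holds the lowest of the two full numbers, with compound 2 nearest; the step of a 1.4-fold lower number from compound 2 to compound 3 (0.14 log units; within the scatter) lies within the scatter, so no order between the two can be read. The step of an at least 2.6-fold lower number from compound 1 to compound 3 (0.42 log units; beyond the scatter) is beyond the scatter, and the step of an at least 1.9-fold lower number from compound 1 to compound 2 (0.28 log units; that floor lies within the scatter) has a floor that sits within it.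

Compound 4 `COc1ccc(-n2nncc2CN2C(=O)C3(C(C#N)=C(N)Oc4c(N)cc5nc6ccccc6nc5c43)c3ccccc32)cc1` is the untested member: 4-methoxyphenyl in place of 3-(trifluoromethyl)phenyl on an aromatic nitrogen. Among the measured compounds shown here, the steps that bear on it are the two that exchanged the 4-fluorophenyl of compound 1 for a ring substituted at the 3-position, and both lowered the number. Returning to a ring substituted at the 4-position, now with methoxy, is expected to raise the number again, although no measured pair contains methoxy. Compound 4 is therefore estimated at 35000 nM, between 12000 nM and 100000 nM. The expected step of a 1.9-fold higher number from compound 3 to compound 4 (0.27 log units; within the scatter) is a modest weakening.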

Compound 4, half-maximal inhibitory concentration: > 50000 nM
Compound 4 ended at the assay's limit; the forecaster's own chance of this, stated with the estimate: 35%; at least 1.4-fold (0.15 log units) between middle value and limit.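

The change to 4-methoxyphenyl gives an at least 2.6-fold higher number from compound 3 to compound 4 (0.42 log units; beyond the scatter), and this step lies beyond the scatter, while an at least 1.9-fold higher number from compound 2 to compound 4 (0.28 log units; that floor lies within the scatter) has a floor that lies within it, so only the first step firmly separates compound 4 from a compound with a full number in this assay. Among the compounds shown here, until now, compound 1 was the only compound that gave no full number, which left open whether that result was particular to its 4-fluorophenyl group, but compound 4 now reaches a limit with a different group on the same nitrogen: the limit of > 50000 nM in this assay, at which 2 of the 4 values shown sit. Across these four compounds, the two groups named with a 4 sit at the limit and the two named with a 3 give full numbers, although the step between compound 1 and compound 4 cannot be read, so fluoro and methoxy cannot be put in order.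

The compounds shown cannot separate where a group sits on the phenyl ring from which group it is, since no group appears there at both places. They also leave open how a plain phenyl ring, or a phenyl ring carrying an amine or a carboxylic acid, would read in this assay.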